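A Ring Exchange on an Amide Nitrogen

The compounds below may be only part of what the source reports. "The series", "measured", "known", "first", "only" and "open" are said of these compounds alone.

In an ADME assay on microsomes from liver (Mus musculus, strain CD-1) for metabolic stability, read by LC-MS, tested at 2 uM (on this read-out higher numbers stand for a longer-lived compound and lower numbers for a shorter-lived compound), compound 1 (`CN(Cc1cncnc1)S(=O)(=O)c1ccccc1Nc1cc(-c2ccc3ccn(C)c3c2)c2nccnc2c1`) gives 0.2 h. Compound 2 (`Cn1cc(NC(=O)c2ccncc2Nc2cc(-c3ccc4ccn(C)c4c3)c3nccnc3c2)cn1`) gives 0.2 h, which places it level with compound 1, within the usual scatter. These two compounds differ in more than one place, so they do not isolate the effect of any single group. Compound 3 (`CN1CCC(NC(=O)c2ccncc2Nc2cc(-c3ccc4ccn(C)c4c3)c3nccnc3c2)CC1=O`) has 1-methyl-2-oxopiperidin-4-yl in place of 1-methyl-1H-pyrazol-4-yl on an amide-type nitrogen. For the measured compounds named here, no measured pair covers this exchange, so the data give no direct guide to its size. Compound 1 at 0.2 h and compound 2 at 0.2 h show the same short half-life despite their different structures, so a slight upward move that stays within the scatter is expected. The expected step is a 1.5-fold higher number from compound 2 to compound 3 (0.18 log units; within the scatter). For compound 3, the estimated half-life in this assay is 0.3 h, with an expected range of 0.15 h to 0.7 h.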

Compound 3, half-life: 0.717 h
Compound 3: the middle estimate sits 2.4-fold (0.38 log units) below what was measured; measured number outside the range, above it.
By their numbers in this assay, from the lowest: compounds 1 and 2 (each within the scatter of the next); then compound 3.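

For the compounds shown here, at the amide-type nitrogen, putting 1-methyl-2-oxopiperidin-4-yl in place of 1-methyl-1H-pyrazol-4-yl gives in this assay a 3.6-fold higher number from compound 2 to compound 3 (0.55 log units; beyond the scatter), the first comparison here that isolates a single change. It shows that the half-life responds to the group on this nitrogen while the rest of the molecule stays the same, which compound 1 and compound 2, differing in more than one place, could not show. No information on why the half-life moves is available for this pair.

The compounds shown leave open which feature of the entering group goes with the step: the non-aromatic six-membered ring or its carbonyl. A 1-methylpiperidin-4-yl group, which has the ring without the carbonyl, would separate the two.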